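Thiophen-3-yl for Methyl on the Shared Core

The source may hold more compounds than are shown below. What is called first, only, known or untested is meant among the compounds shown, and "the series" means these compounds.

Compound 1, `CN1CCCN(CCn2ccc3ccc(Br)cc32)CC1`, gives 31 nM in an assay on HEK293 cells for binding affinity to 5-hydroxytryptamine receptor 7 (Homo sapiens), read by radioligand binding; on this read-out lower numbers stand for stronger inhibition and higher numbers for weaker inhibition. Compound 2, `C#Cc1ccc2ccn(CCN3CCCN(C)CC3)c2c1`, gives 140 nM in this assay. Compound 3, `Cc1ccc2ccn(CCN3CCCN(C)CC3)c2c1`, gives 125 nM in this assay.

Compound 3 stands apart from compound 1 by a 4.0-fold higher number from compound 1 to compound 3 (0.61 log units; beyond the scatter), while against compound 2 the difference is a 1.1-fold lower number from compound 2 to compound 3 (0.05 log units; within the scatter), so compound 3 and compound 2 cannot be told apart. Compound 4, `CN1CCCN(CCn2ccc3ccc(-c4ccsc4)cc32)CC1`, differs from compound 3 in one place: thiophen-3-yl in place of methyl on an aromatic carbon.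

Among the compounds with values here, no measured step exchanges a small group for a ring at this position. The steps that come nearest are a 4.5-fold higher number from compound 1 to compound 2 (0.65 log units; beyond the scatter) and a 4.0-fold higher number from compound 1 to compound 3 (0.61 log units; beyond the scatter), which show that bromo at this place gives a lower number than either ethynyl or methyl, and a 1.1-fold lower number from compound 2 to compound 3 (0.05 log units; within the scatter), which shows that ethynyl and methyl behave alike. Whether a larger aromatic group moves the number the way bromo does is not shown, so a wide range is warranted. Compound 4 is therefore estimated at 80 nM, with a range from 20 nM to 320 nM, a change expected to be no more than a 1.6-fold lower number from compound 3 to compound 4 (0.19 log units; within the scatter).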

Compound 4, inhibition constant: 109 nM
For compound 4 the middle estimate is 1.4-fold (0.13 log units) below the measured one, and the stated range covers the measured number.
By their numbers in this assay, from the lowest: compound 1; then compounds 4, 3 and 2 (each within the scatter of the next).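

Exchanging methyl for the five heavy atoms of thiophen-3-yl gives a number in this assay that cannot be told apart from that of compound 3, with a 1.1-fold lower number from compound 3 to compound 4 (0.06 log units; within the scatter), and the same holds against ethynyl, with a 1.3-fold lower number from compound 2 to compound 4 (0.11 log units; within the scatter). The thiophen-3-yl ring does not match bromo, with a 3.5-fold higher number from compound 1 to compound 4 (0.55 log units; beyond the scatter), so among the four groups shown at this place, bromo alone stands apart from the other three, and a larger aromatic group does not move the number the way bromo does. Nothing available explains why bromo differs from the other groups.

The compounds shown leave open whether chloro or iodo at this place would give a number like that of compound 1. They also leave open whether phenyl, thiophen-2-yl, an amine or a carboxylic acid there would behave like thiophen-3-yl.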